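The source may report more compounds than this note shows. Statements on the series, on what has been measured and on what is new or still open speak of the compounds shown alone.

Measured so far:
- compound 1, `CCCCc1cnc(C(CC)Cc2ccc(-c3ccccc3C(=O)O)cc2)[nH]1`, 340 nM
- compound 2, `CC(C)(C)Cc1cnc(CCc2ccc(-c3ccccc3C(=O)O)cc2)[nH]1`, 6.3 nM

Both were run in an in vitro functional assay on cells for agonist activity at Bombesin receptor subtype-3 (Mus musculus), read by luminescence and calcium flux; a lower number here means that less compound is needed, a higher number that more compound is needed for the effect. Compound 1 gives 340 nM in this assay, whereas compound 2 gives 6.3 nM; compound 2 thus has the lower of the two numbers, and its gap to compound 1 lies well beyond the scatter. The two differ in more than one place, so nothing is said here of any single cause.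

Compound 3, `O=C(O)c1ccccc1-c1ccc(CCc2ncc(CC3CCCC3)[nH]2)cc1`, has not been measured. It differs from compound 2 in one place: cyclopentyl in place of tert-butyl on a saturated chain carbon bound to an aromatic carbon. Among the measured compounds shown here, no step between two measured compounds isolates a change of this kind, so the expectation rests on compound 2 alone. Cyclopentyl and tert-butyl are both saturated carbon groups without donors or acceptors, so the expected step of a 1.4-fold higher number from compound 2 to compound 3 (0.15 log units; within the scatter) is small, in either direction, and within the usual scatter. Compound 3 is therefore expected near 9 nM, with a range from 3 nM to 35 nM.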

Compound 3, half-maximal effective concentration: 7.9 nM
Estimate against measurement, compound 3: 1.1-fold (0.06 log units) above, within the range that was stated.
By their numbers in this assay, from the lowest: compounds 2 and 3 (each within the scatter of the next); then compound 1.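

In this assay, cyclopentyl in place of tert-butyl on a saturated chain carbon bound to an aromatic carbon gives a 1.3-fold higher number from compound 2 to compound 3 (0.10 log units; within the scatter), so at this position the ring-bearing group and the open-chain group cannot be told apart. Among the compounds shown here, this is the only step that isolates one change, which the comparison of compound 1 with compound 2 could not do, as those two differ in more than one place. Nothing measured here bears on why the two groups read alike.

As far as these compounds go, the position has been read only with these two saturated carbon groups, so the outcome with an amine, a hydroxyl group, a phenyl ring or a longer chain stays open. The gap between compound 1 and compound 2 also remains unassigned to any single place.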